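The source may hold more compounds than are shown below. What is called first, only, known or untested is meant among the compounds shown, and "the series" means these compounds.

Compounds measured in a functional assay for antagonist activity at 5-hydroxytryptamine receptor 4 (Rattus norvegicus); on this read-out lower numbers stand for lower potency and higher numbers for higher potency (the scale is a negative logarithm):
compound 1, `COc1ccc(COc2cc(N)c(Cl)cc2C(=O)CCCCN2CCCCC2)cc1OC`; compound 1 gives 8.5
compound 2, `CCCC1CCN(CCCCC(=O)c2cc(Cl)c(N)cc2OCc2cc(OC)cc(OC)c2)CC1`; compound 2 gives 7.7
compound 3, `COc1cc(COc2cc(N)c(Cl)cc2C(=O)CCCCN2CCC(O)CC2)cc(OC)c1`; compound 3 gives 8.3

Compound 3 stands second highest of the three numbers in this assay. Its nearest neighbour is compound 1, whose number lies within the scatter of that of compound 3, so no order between those two can be read. Among the measured compounds shown here, the one step in this set that lies beyond the scatter is a number 0.60 log units higher from compound 2 to compound 3 (beyond the scatter), a modest gain.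

Compound 4, `COc1cc(COc2cc(N)c(Cl)cc2C(=O)CCCCN2CCC(NC(N)=O)CC2)cc(OC)c1`, differs from compound 3 in one place: ureido in place of hydroxy on a saturated ring carbon. For the measured compounds named here, only that single measured step touches this position, and it exchanged propyl for hydroxy, not hydroxy for ureido; no measured pair shows the ureido group at all. That step therefore gives only a weak guide: the position has accepted a change of group once without loss, but the direction for ureido is not shown. The expected step is a number 0.10 log units lower from compound 3 to compound 4 (within the scatter), within the scatter. Compound 4 is estimated at 8.2, within 7.5 to 8.9.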

Compound 4, negative logarithm of the antagonist equilibrium constant: 8.5
Compound 4: middle estimate off by 0.30 log units, on the low side, within the range that was stated.
By their numbers in this assay, from the lowest: compound 2; then compounds 3, 1 and 4 (each within the scatter of the next).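

In this assay ureido in place of hydroxy on the saturated ring carbon gives a number 0.20 log units higher from compound 3 to compound 4 (within the scatter) and so the two groups cannot be ordered, even though ureido brings 4 heavy atoms where hydroxy has 1. Ureido in place of propyl gives a number 0.80 log units higher from compound 2 to compound 4 (beyond the scatter) and so propyl now stands beyond the scatter below two different groups at this position, not only below hydroxy. No evidence on the cause of these steps is available in this set.

As far as these compounds go, whether an amine, a carboxylic acid or a chain longer than propyl on this ring carbon would keep the number at this level remains open. From the compounds shown here alone, the unsubstituted ring is also open for this core, since compound 1 differs from the other compounds in more than one place and cannot serve as the comparison.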